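Chloro in place of nitro: a single anchor value

The source may report more compounds than this note shows. Statements on the series, on what has been measured and on what is new or still open speak of the compounds shown alone.

In a functional assay on the whole organism (strain albino) with Mus musculus as the target, with a stated time of 0.5 h (on this read-out lower numbers stand for an effect already at smaller amounts and higher numbers for an effect only at larger amounts of compound), compound 2 `CC(=O)N1N=C(Nc2nc3ccc([N+](=O)[O-])cc3s2)CC1c1ccc(Cl)cc1` gives 138 umol/kg. Among the compounds with values here, this is the only number so far, so compound 2 cannot yet be ranked against anything. For compound 1 `CC(=O)N1N=C(Nc2nc3ccc(Cl)cc3s2)CC1c1ccccc1` the entry in this assay reads "not determined" (no result reported), with no result reported, and it offers no comparison.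

Compound 3 `CC(=O)N1N=C(Nc2nc3ccc(Cl)cc3s2)CC1c1ccc(Cl)cc1` has not been measured. It carries chloro in place of nitro on an aromatic carbon of a six-membered aromatic ring of carbon only, part of a fused or bridged system of two rings: chloro in place of nitro on an aromatic carbon. Within the data shown here, no measured pair shows what this exchange does, so neither the size nor the direction of the step can be taken from data. Among the measured compounds shown here, the expected change is a 1.1-fold lower number from compound 2 to compound 3 (0.04 log units; within the scatter), a step not beyond the scatter and with no firm direction, and its only anchor is compound 2 at 138 umol/kg. For compound 3 the estimated value in this assay is 125 umol/kg, with an expected range from 50 umol/kg to 310 umol/kg.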

Compound 3, dose for half-maximal effect: 81.5 umol/kg
For compound 3 the middle estimate is 1.5-fold (0.19 log units) above the measured one; the range from low to high includes it.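

In this assay, within the data shown here, the exchange of chloro in place of nitro on an aromatic carbon gives a 1.7-fold lower number from compound 2 to compound 3 (0.23 log units; within the scatter) and is the first reading for this position. One heavy atom with no hydrogen-bond acceptors enters where three heavy atoms with two hydrogen-bond acceptors leave, and the two compounds still cannot be told apart on this read-out, so this single pair shows that the position accepts both groups. Nothing available on this pair bears on why the two groups read alike.

As far as these compounds go, the step from compound 1 to compound 3 cannot be read, as compound 1 gives "not determined" (no result reported) in this assay, so what the chloro on the other aromatic ring contributes stays unknown. With only nitro and chloro shown at this position, it remains open whether an amine, a carboxylic acid or a methoxy group there would also stay within the scatter of compound 3 or would move the dose for half-maximal effect clearly in either direction.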